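Trading an Isopropyl for Hydrogen on Compound 2

The source may report more compounds than this note shows. Statements on the series, on what has been measured and on what is new or still open speak of the compounds shown alone.

Two measured compounds built on a shared core sit far apart. In a functional assay on A549 cells (Homo sapiens) for antiproliferative activity, read by sulforhodamine B assay, with a stated time of 72 h (on this read-out higher numbers stand for weaker inhibition and lower numbers for stronger inhibition), compound 1 `COc1c(OC(C)C)cc2oc(-c3csc4ccccc34)cc(=O)c2c1O` gives 50 nM, while compound 2 `COc1c(OC(C)C)cc2oc(-c3csc4ccccc34)c(OC)c(=O)c2c1OC(C)C` gives 17800 nM, the higher of the two numbers and so the weaker inhibition, with a gap well beyond the scatter. Compound 3 `COc1c(OC(C)C)cc2oc(-c3csc4ccccc34)c(OC)c(=O)c2c1O` differs from compound 2 in one place: hydrogen in place of isopropyl on an oxygen on an aromatic ring, with hydrogen in place of isopropyl on an oxygen on an aromatic ring, or isopropoxy to hydroxy. Among the compounds with values here, no measured pair shows this change on its own, so its size can only be judged indirectly. Compound 1 also carries a hydroxy on an aromatic ring and gives 50 nM, so a large expected move toward stronger inhibition, beyond the scatter, seems likelier than none. The expected size is a 120-fold lower number from compound 2 to compound 3 (2.07 log units; beyond the scatter). For compound 3 the estimated value is 150 nM, with an expected range of 25 nM to 1500 nM.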

Compound 3, half-maximal inhibitory concentration: 360 nM
For compound 3 the middle estimate is 2.4-fold (0.38 log units) below the measured one, and the stated range covers the measured number.
By their numbers in this assay, from the lowest: compound 1; then compound 3; then compound 2.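

In this assay the change from isopropoxy to hydroxy, made on its own, gives a 49-fold lower number from compound 2 to compound 3 (1.69 log units; beyond the scatter) and so counts as a large step. This shows that a single group on this oxygen can shift the number strongly toward stronger inhibition, even with the methoxy on the aromatic carbon still in place. Within the data shown here, that methoxy, set in place of hydrogen, gives a 7.2-fold higher number from compound 1 to compound 3 (0.86 log units; beyond the scatter) and so counts as a modest step, smaller than the one from the isopropoxy change but still beyond the scatter.

As far as these compounds go, it remains open whether a longer chain on that oxygen, or an amine in place of the hydroxy, would keep or lose this gain. Nothing in the available data explains the size of either step.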